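Amide-aryl swaps on a shared core: flat so far

The source may report more compounds than this note shows. Statements on the series, on what has been measured and on what is new or still open speak of the compounds shown alone.

Three compounds share one core and differ only in the aryl group on the amide carbonyl. Compound 1 `COc1cc(F)c(NC(=O)c2ccncc2)cc1Nc1nccc(-c2cn(C)c3ccccc23)n1` gives 4370 nM in a functional assay on NCI-H1975 cells (Homo sapiens) for antiproliferative activity, read by MTT assay, with a stated time of 72 h; a lower number here means a stronger inhibitor, a higher number a weaker inhibitor. Compound 2 `COc1cc(F)c(NC(=O)c2ccnc(Cl)c2)cc1Nc1nccc(-c2cn(C)c3ccccc23)n1` gives 4330 nM in this assay, and compound 3 `COc1cc(F)c(NC(=O)c2ccncc2OC)cc1Nc1nccc(-c2cn(C)c3ccccc23)n1` gives 4120 nM. Compound 2 stands second highest of the three numbers, but every gap among them is within the scatter: a 1.0-fold lower number from compound 1 to compound 2 (0.00 log units; within the scatter), a 1.1-fold lower number from compound 1 to compound 3 (0.03 log units; within the scatter) and a 1.1-fold lower number from compound 2 to compound 3 (0.02 log units; within the scatter). Across this small set the aryl group on the amide has not moved the number.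

Compound 4 `COc1cc(F)c(NC(=O)c2ncccn2)cc1Nc1nccc(-c2cn(C)c3ccccc23)n1` has not yet been measured. From compound 2 the change is pyrimidin-2-yl in place of 2-chloropyridin-4-yl on a carbonyl carbon. Among the compounds with values here, no measured step makes exactly this exchange; the steps that bear on it are the three amide-aryl swaps above, all of them flat. The expectation for this assay is therefore a step of a 1.0-fold lower number from compound 2 to compound 4 (0.00 log units; within the scatter), that is, none beyond the scatter. Compound 4 is estimated at 4300 nM, with a range from 1800 nM to 10000 nM.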

Compound 4, half-maximal inhibitory concentration: 13500 nM
For compound 4 the middle estimate is 3.1-fold (0.50 log units) below the measured one; measured number outside the range, above it.
By their numbers in this assay, from the lowest: compounds 3, 2 and 1 (each within the scatter of the next); then compound 4.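

In this assay the group on the carbonyl carbon is not without effect: pyrimidin-2-yl gives a 3.1-fold higher number from compound 2 to compound 4 (0.49 log units; beyond the scatter) and a 3.3-fold higher number from compound 3 to compound 4 (0.52 log units; beyond the scatter) and a 3.1-fold higher number from compound 1 to compound 4 (0.49 log units; beyond the scatter) as the only change shown that goes beyond the scatter. Pyridin-4-yl, 2-chloropyridin-4-yl and 3-methoxypyridin-4-yl remain within the scatter of one another, so the flat picture holds for these three groups only, and all movement so far is towards a higher number. No measurement shown here accounts for the step.

The exchange alters the ring hetero atoms and the point of attachment together, and pyridin-2-yl or pyrimidin-4-yl on the same carbonyl would help separate the two. As far as these compounds go, whether any group at this position, such as a morpholine or another aliphatic amine, can give a lower number than the three pyridinyl compounds remains open.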